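Cytotoxicity notes: from compound 2 to compound 4

The source may hold more compounds than are shown below. What is called first, only, known or untested is meant among the compounds shown, and "the series" means these compounds.

- compound 1 `COCOc1cccc(C(=O)/C=C/c2ccc3c(c2)B(O)OC3)c1` gives > 10 ug/mL as a limit
- compound 2 `COc1cccc(C(=O)CCc2ccc3c(c2)B(O)OC3)c1` gives > 10 ug/mL as a limit
- compound 3 `O=C(/C=C/c1ccc2c(c1)B(O)OC2)c1ccc(Br)cc1` gives > 10 ug/mL as a limit

In an ADME assay on L929 cells (Mus musculus) for cytotoxicity, read by resazurin assay, with a stated time of 72 h (on this read-out higher numbers stand for weaker inhibition and lower numbers for stronger inhibition), compound 2 has only a limit, > 10 ug/mL, and no number. Going by the values given here, the whole set stands at the limit of > 10 ug/mL in this assay, at which 3 of the 3 values shown sit, and no compound can be ranked. Compound 4 `O=C(CCc1ccc2c(c1)B(O)OC2)c1ccccc1` differs from compound 2 by hydrogen in place of methoxy on an aromatic carbon, meta to a large group. Among the compounds with values here, no measured step covers this change. With compound 2 at > 10 ug/mL as a limit, no shift beyond the scatter is expected in this assay in either direction. The expected size of the change is a step that the limit leaves unreadable from compound 2 to compound 4 as an estimate. For compound 4 the estimated value is 15 ug/mL with an expected range of 8 ug/mL to 40 ug/mL and a report as a limit is likely.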

Compound 4, half-maximal inhibitory concentration: > 10 ug/mL
Compound 4: no number, only a limit; the forecaster's own chance of this, stated with the estimate: 85%; the middle value lies beyond the limit too.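

No step can be read between compound 2 and compound 4, as both stand only as limits in this assay: the limit of > 10 ug/mL in this assay, at which 4 of the 4 values shown sit.

The compounds shown leave open whether hydrogen or methoxy on the aromatic carbon changes cytotoxicity at all, since none of them gives a number.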